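The compounds below may be only part of what the source reports. "The series", "measured", "known", "first", "only" and "open" are said of these compounds alone.

Measured in a functional assay on HeLa cells (Homo sapiens) for antiproliferative activity, read by MTT assay, with a stated time of 48 h; a lower number here means a stronger inhibitor, a higher number a weaker inhibitor:
- compound 1 `COC(=O)[C@H](CC(C)C)NC(=O)c1ccc(Oc2nc3ccc(Cl)cc3nc2C)cc1`: 37600 nM
- compound 2 `COC(=O)CNC(=O)c1ccc(Oc2nc3ccccc3nc2NC(C)(C)C)cc1`: > 50000 nM

Compound 2 stands at the limit of > 50000 nM in this assay, at which 1 of the 2 values shown sits. Its reading is a limit of the assay and not a number. Going by the values given here, the only numerical reading is that of compound 1, at 37600 nM, and it shows weak inhibition.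

Compound 3 `CC[C@@H](C)[C@H](NC(=O)c1ccc(Oc2nc3ccccc3nc2NC(C)(C)C)cc1)C(=O)O` keeps the core of compound 2 and carries 1-carboxy-2-methylbutyl in place of (methoxycarbonyl)methyl on an amide-type nitrogen. Among the compounds with values here, no measured pair in this small set shows what such a change does. In this assay, no step beyond the usual scatter is therefore expected, and another reading at the limit would be no surprise. The expected size of the change is an at least 1.1-fold lower number from compound 2 to compound 3 (0.04 log units; that floor lies within the scatter). For compound 3 the estimated value is 45000 nM, with an expected range from 15000 nM to 80000 nM.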

Compound 3, half-maximal inhibitory concentration: 13400 nM
Estimate against measurement, compound 3: 3.4-fold (0.53 log units) above; measured number below the stated range.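

Compound 2 gives no number in this assay, only a limit: the limit of > 50000 nM in this assay, at which 1 of the 3 values shown sits.

Going by these compounds alone, on the amide-type nitrogen, 1-carboxy-2-methylbutyl in place of (methoxycarbonyl)methyl gives an at least 3.7-fold lower number from compound 2 to compound 3 (0.57 log units; beyond the scatter), so this position can move the reading on this core, which the earlier compounds, differing in more than one place, could not show. The exchange alters several features at once: a carboxy group replaces the methoxycarbonyl, and a longer branched chain with defined stereocentres enters, so the step cannot be assigned to any one of these.

The compounds shown leave open whether the carboxy group or the branched chain accounts for the step; carboxymethyl on the same nitrogen would separate the two. As far as these compounds go, whether a primary carboxamide in place of the carboxy group would keep the reading also remains open.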